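The source may hold more compounds than are shown below. What is called first, only, known or untested is meant among the compounds shown, and "the series" means these compounds.

Compound 1 `COc1ccc(C(=O)O)cc1OCCCCOc1ccc(C(=O)CC2CCCC2)c(O)c1C` and compound 2 `COc1ccc(C(=O)O)cc1OCCCCOc1ccc(C(C)=O)c(O)c1C` share one core. In an assay on HEK293 cells for positive allosteric modulation of metabotropic glutamate receptor 3 (Rattus norvegicus), read by thallium flux, with a stated time of 2.5 min (a higher number here means a larger maximal response, a lower number a smaller maximal response), compound 1 gives 67.6%, while compound 2 gives 34.8%, the lower of the two numbers. Within the data shown here, the single measured step, a number 32.8 percentage points lower from compound 1 to compound 2 (beyond the scatter), followed the loss of the cyclopentyl. Compound 3 `COc1ccc(C(=O)O)cc1OCCCCOc1ccc(C(=O)CC(C)C)c(O)c1C` differs from compound 2 by isopropyl in place of hydrogen on a saturated chain carbon bound to a carbonyl carbon. The entering isopropyl has no ring, unlike the cyclopentyl that left in a number 32.8 percentage points lower from compound 1 to compound 2 (beyond the scatter), so a rise is expected, but a smaller one than that drop. The estimated step is a number 17.2 percentage points higher from compound 2 to compound 3 (beyond the scatter). Compound 3 is thus expected to reach about 52%, within a range from 38% to 68%.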

Compound 3, largest response reached (reported as percent of maximum), in percent of the reference or control that the assay uses: 100%
Beside the measured number, compound 3's estimate is 48 percentage points below it; the measured number lies above the stated range.
By their numbers in this assay, from the lowest: compound 2; then compound 1; then compound 3.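

On the saturated chain carbon bound to a carbonyl carbon, putting isopropyl in place of hydrogen gives a number 65.2 percentage points higher from compound 2 to compound 3 (beyond the scatter) in this assay. Putting isopropyl in place of cyclopentyl gives a number 32.4 percentage points higher from compound 1 to compound 3 (beyond the scatter), so a ring at this place is not needed for a large maximal response, and the ring-free isopropyl gives the largest response of the three. Nothing shown here offers a reason for this order. The compounds shown leave open how a tert-butyl, a longer chain or an amine at this same place would compare with isopropyl.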